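The source may report more compounds than this note shows. Statements on the series, on what has been measured and on what is new or still open speak of the compounds shown alone.

Of the compounds shown here, three sharing one core have been measured in a functional assay on NCI-H460 cells (Homo sapiens) for cytotoxicity, read by MTT assay, with a stated time of 72 h; on this read-out higher numbers stand for weaker inhibition and lower numbers for stronger inhibition. Compound 1, `CN(C)CCn1cnnc1-c1cc(Oc2ccc(NC(=O)N/N=C/c3c[nH]c4ccccc34)cc2F)ccn1`, gives 1630 nM in this assay, the lowest of the three numbers, though its steps to both of the others stay within the scatter. Compound 2, `COc1ccc(OC)c(/C=N/NC(=O)Nc2ccc(Oc3ccnc(-c4nncn4CCN(C)C)c3)c(F)c2)c1`, gives 2930 nM in this assay, and compound 3, `COc1ccc(/C=N/NC(=O)Nc2ccc(Oc3ccnc(-c4nncn4CCN(C)C)c3)c(F)c2)c(OC)c1OC`, gives 1790 nM. The change a 1.8-fold higher number from compound 1 to compound 2 (0.25 log units; within the scatter) and the change a 1.1-fold higher number from compound 1 to compound 3 (0.04 log units; within the scatter) each exchange the same group for a substituted phenyl ring; the remaining pair, a 1.6-fold lower number from compound 2 to compound 3 (0.21 log units; within the scatter), also stays within the scatter.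

Compound 4, `CN(C)CCn1cnnc1-c1cc(Oc2ccc(NC(=O)N/N=C/c3ccc(O)c(F)c3)cc2F)ccn1`, differs from compound 1 by a single change: 3-fluoro-4-hydroxyphenyl in place of 1H-indol-3-yl on a carbon with a double bond to nitrogen. The two measured steps that bear on this, those from compound 1 to compound 2 and from compound 1 to compound 3, both replace the 1H-indol-3-yl with a six-membered aromatic ring of carbon only on the carbon with a double bond to nitrogen, and neither moved beyond the scatter. Among the measured compounds shown here, no measured compound separates a hydroxy and fluorine substitution from methoxy substitution, so the expectation rests on those two steps alone. Compound 4 is therefore expected to show no step beyond the scatter in this assay, an estimated 1.2-fold higher number from compound 1 to compound 4 (0.09 log units; within the scatter). The value of compound 4 is estimated at 2000 nM, with a range from 900 nM to 4500 nM.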

Compound 4, half-maximal inhibitory concentration: 2620 nM
The estimate for compound 4 lay 1.3-fold (0.12 log units) below the measured number; the measured number falls inside the stated range.
By their numbers in this assay, from the lowest: compounds 1, 3, 4 and 2 (each within the scatter of the next).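

In this assay, placing 3-fluoro-4-hydroxyphenyl instead of 1H-indol-3-yl on the carbon with a double bond to nitrogen gives a step that stays within the scatter (a 1.6-fold higher number from compound 1 to compound 4 (0.21 log units; within the scatter)), so a ring bearing a hydroxy group and a fluorine now joins the two methoxy-bearing rings in showing no measurable departure from the indole compound. The new ring is also not separated from either methoxy-bearing ring, with a 1.5-fold higher number from compound 3 to compound 4 (0.17 log units; within the scatter) against the 2,3,4-trimethoxyphenyl group and a 1.1-fold lower number from compound 2 to compound 4 (0.05 log units; within the scatter) against the 2,5-dimethoxyphenyl group, so all four compounds now lie within the scatter of one another and this read-out has yet to distinguish any of these aromatic groups at this position. Nothing given here accounts for these numbers or explains this lack of separation.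

As far as these compounds go, all four compounds carry an aromatic ring at this place, so it remains open whether a group of another kind there, such as an amine, a carboxylic acid or a longer alkyl chain, would move the number beyond the scatter. From the compounds shown here alone, the separate contributions of the hydroxy group and the fluorine of the 3-fluoro-4-hydroxyphenyl group also remain open.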